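The source may hold more compounds than are shown below. What is called first, only, known or untested is meant among the compounds shown, and "the series" means these compounds.

In a functional assay on HL-60 cells (Homo sapiens) for antiproliferative activity, read by XTT assay, with a stated time of 72 h (on this read-out higher numbers stand for weaker inhibition and lower numbers for stronger inhibition), compound 3 (`Cc1nc(N)c2c(-c3cccs3)cn([C@@H]3O[C@H](CO)[C@@H](O)[C@H]3O)c2n1`) gives > 20000 nM, which is a limit and not a number. Compound 2 (`Nc1nc(N)c2c(-c3cccs3)cn([C@@H]3O[C@H](CO)[C@@H](O)[C@H]3O)c2n1`) gives > 20000 nM, which is also a limit. Between these two lies a step that the two limits leave unreadable from compound 2 to compound 3, so the only measured step offers no size to build on. Compound 4 (`C#Cc1cn([C@@H]2O[C@H](CO)[C@@H](O)[C@H]2O)c2nc(C)nc(N)c12`) keeps the methyl of compound 3 and changes elsewhere: ethynyl in place of thiophen-2-yl on an aromatic carbon, with ethynyl in place of thiophen-2-yl. Compound 1 (`C#Cc1cn([C@@H]2O[C@H](CO)[C@@H](O)[C@H]2O)c2ncnc(SC)c12`), which also carries ethynyl, gives 50 nM, although it differs from compound 4 in more than one place. On that single hint, stronger inhibition is expected, an estimated at least 5.0-fold lower number from compound 3 to compound 4 (0.69 log units; beyond the scatter). Compound 4 is expected at 4000 nM, within an estimated range of 300 nM to 20000 nM.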

Compound 4, half-maximal inhibitory concentration: > 20000 nM
Compound 4: a limit, no number; the forecaster's own chance of this, stated with the estimate: 45%; at least 5.0-fold (0.69 log units) between middle value and limit.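

Among these compounds, compound 3 and compound 4 each give only a limit, not a number, so no step between them can be read: the limit of > 20000 nM in this assay, at which 3 of the 4 values shown sit. On these data alone, whether thiophen-2-yl or ethynyl gives stronger inhibition on this shared core stays open.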